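A pyridine swap on a shared nitrocatechol core

The source may hold more compounds than are shown below. What is called first, only, known or untested is meant among the compounds shown, and "the series" means these compounds.

Three compounds have been measured so far:
Compound 1, `O=[N+]([O-])c1cc(-c2nc(-c3ccc(Br)cc3)no2)cc(O)c1O`, gives 12.7% in a functional assay on the whole organism (liver, strain NMRI) for inhibition, with Mus musculus as the target, with a stated time of 3 h, at a dose of 3 mg/kg by the oral route; a higher number here means more inhibition at the dose given (going by the name of the read-out), a lower number less inhibition.
Compound 2, `CC(=O)N1CCN(c2noc(-c3cc(O)c(O)c([N+](=O)[O-])c3)n2)CC1`, gives 68.2% in this assay.
Compound 3, `O=[N+]([O-])c1cc(-c2cc(-c3cccnc3)no2)cc(O)c1O`, gives 33.6% in this assay.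

Among these three, compound 3 stands second, with compound 1 lower and compound 2 higher, and both gaps lie beyond the usual scatter of repeated measurements. Compound 4, `Cc1ccc(-c2cc(-c3cc(O)c(O)c([N+](=O)[O-])c3)on2)c(Cl)n1`, has not been measured yet. It differs from compound 3 in one place: 2-chloro-6-methylpyridin-3-yl in place of pyridin-3-yl on an aromatic carbon. The change keeps the same kind of six-membered aromatic ring with one hetero atom and adds two heavy atoms to it. Among the measured compounds shown here, no measured pair shows what such a change does in this assay, so there is nothing here to tell the size or direction of the step; the expectation is a step that stays within the scatter. On that basis compound 4 is estimated at 35%, with a likely range from 10% to 60%, which would mean an expected step of a number 1.4 percentage points higher from compound 3 to compound 4 (within the scatter).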

Compound 4, a percentage reported as inhibition, in the whole organism at one dose (the size of the read-out at that dose, not a potency): 21.6%
Estimate against measurement, compound 4: 13.4 percentage points above; the range from low to high includes it.
By their numbers in this assay, from the lowest: compounds 1 and 4 (each within the scatter of the next); then compound 3; then compound 2.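

In this assay, placing 2-chloro-6-methylpyridin-3-yl instead of pyridin-3-yl on this aromatic carbon, next to the ring nitrogen, gives a number 12 percentage points lower from compound 3 to compound 4 (beyond the scatter) as a step beyond ordinary noise. Among the compounds shown here, this is the first direct reading at this position, and it shows that the number responds to a change on the pyridine ring even though the ring type and the hydrogen-bond donor and acceptor counts stay the same and only two heavy atoms are added. Nothing available explains why the number falls.

Chlorine and methyl arrive together here, so it remains open which of them, or whether the pair, accounts for the step. Also open, going by these compounds, is how an amine or a carboxylic acid on the pyridine ring would read at this position.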